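The source may hold more compounds than are shown below. What is called first, only, known or untested is meant among the compounds shown, and "the series" means these compounds.

Compound 2 `Cc1cccc(C(=O)c2ccn(-c3ccc4c(c3)B(O)OC4)c2)c1` was tested in an ADME assay on L929 cells (Mus musculus) for cytotoxicity, read by resazurin assay, with a stated time of 72 h; a lower number here means a stronger inhibitor, a higher number a weaker inhibitor. In this assay compound 2 gives > 10 ug/mL, which is a limit of the assay rather than a number. Compound 1 `O=C(c1ccn(-c2ccc3c(c2)B(O)OC3)c1)c1ccc(Cl)cc1Cl` gives in this assay > 10 ug/mL, also a limit. Within the data shown here, the only measured step that changes one place, 3-methylphenyl in place of 2,4-dichlorophenyl on a carbonyl carbon, therefore cannot be read: a step that the two limits leave unreadable from compound 1 to compound 2. Among the measured compounds shown here, compound 3 `CC(=O)OCc1ccc(C(=O)c2ccn(-c3ccc4c(c3)B(O)OC4)c2)cc1` gives in this assay 10 ug/mL, the one number among the three values shown. Two of the three values sit at the same place, (the limit of > 10 ug/mL in this assay, at which 2 of the 3 values shown sit).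

Compound 4 `O=C(CCc1ccccc1)c1ccn(-c2ccc3c(c2)B(O)OC3)c1` differs from compound 2 by phenethyl in place of 3-methylphenyl on a carbonyl carbon. For the measured compounds named here, no measured step bears directly on this change, and the one measured step is unreadable. With two limits and one number close to that limit, there is no ground to expect a step beyond the scatter in this assay, so the estimated step is a number no higher from compound 2 to compound 4 (the limit leaves the size open). Compound 4 is thus estimated at 10 ug/mL, with a range from 5 ug/mL to 20 ug/mL, and a fair chance that only a limit is reported again.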

Compound 4, half-maximal inhibitory concentration: > 10 ug/mL
Compound 4: no number, only a limit; the forecaster's own chance of this, stated with the estimate: 60%; the middle value lies on the limit itself.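

In this assay compound 4 gives > 10 ug/mL, a limit of the assay and not a number. Its steps from compound 1 and from compound 2 therefore cannot be read: the limit of > 10 ug/mL in this assay, at which 3 of the 4 values shown sit. The compounds shown leave open whether 2,4-dichlorophenyl, 3-methylphenyl or phenethyl on the carbonyl carbon makes any difference in this assay.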